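The source may hold more compounds than are shown below. What is called first, only, known or untested is meant among the compounds shown, and "the series" means these compounds.

Measured compounds:
- compound 1, `COc1ccc(Sc2ccc(Cl)cc2N2CCN(CC(=O)O)C(C)C2)cc1`: 290 nM
- compound 2, `COc1ccc(Sc2ccccc2N2C[C@@H](C)N(CC(=O)O)C[C@H]2C)cc1`: 16000 nM
- compound 3, `COc1ccc(Sc2ccccc2N2CCN(CC(=O)O)CC2C)cc1`: > 10000 nM

All three compounds share the same core and were tested in an assay for inhibition of sodium- and chloride-dependent glycine transporter 1 (Homo sapiens); a lower number here means a stronger inhibitor, a higher number a weaker inhibitor. Compound 1 gives 290 nM, the lowest number among the compounds with a numerical result. Compound 2 gives 16000 nM, a much higher number, and the gap to compound 1 lies well beyond the usual scatter. For compound 3 only a limit of the assay is known: it gives > 10000 nM, which is not a number but the point at which the assay stops reporting (the limit of > 10000 nM in this assay, at which 1 of the 3 values shown sits).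

Compound 4, `COc1ccc(Sc2ccc(OC)cc2N2CCN(CC(=O)O)C(C)C2)cc1`, differs from compound 1 in one place: methoxy in place of chloro on an aromatic carbon. Among the compounds with values here, no measured pair shows the effect of this exact change, so the expectation rests on compound 1 alone. In this assay compound 4 is expected to give a somewhat higher number than compound 1, a step of modest size that may or may not exceed the scatter; the estimated step is a 2.4-fold higher number from compound 1 to compound 4 (0.38 log units; beyond the scatter). The estimate for compound 4 is 700 nM, with a likely range from 200 nM to 3000 nM.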

Compound 4, half-maximal inhibitory concentration: 4600 nM
Compound 4: the middle estimate sits 6.6-fold (0.82 log units) below what was measured; the measured number lies above the stated range.
By their numbers in this assay, from the lowest: compound 1; then compound 4; then compound 2.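

In this assay, the aromatic carbon para to the (4-methoxyphenyl)sulfanyl group proves sensitive to which group it carries: putting methoxy in place of chloro gives a 16-fold higher number from compound 1 to compound 4 (1.20 log units; beyond the scatter), a large loss of inhibition. The earlier compounds shown here could not show this, as neither compound 2 nor compound 3 differs from compound 1 in only one place. Chloro and methoxy are therefore not interchangeable at this carbon, although nothing measured here explains the gap.

On these data alone, whether fluoro, methyl, nitrile or an amine at this carbon would stay close to compound 1 or fall towards compound 4 remains open. So does whether the same change would carry the same cost in compounds with their methyl groups placed elsewhere on the shared core.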